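Swapping an ethyl group for hydrogen on compound 3

The compounds below may be only part of what the source reports. "The series", "measured", "known", "first", "only" and "open" are said of these compounds alone.

Compound 1 `C=C(c1cc(OC)c(OC)c(OC)c1)c1ccc(OC)cc1NC(=O)CO`: 30 nM
Compound 2 `C=C(c1ccc(OC)cc1NC(=O)CNCC)c1ccc(OC)c2c1C=CC(C)(C)O2`: 2590 nM
Compound 3 `C=C(c1cc(OC)c(OC)c(OC)c1)c1ccc(OC)c(O)c1NC(=O)COCC`: 690 nM

All three values come from a functional assay on HeLa cells (Homo sapiens) for antiproliferative activity, read by MTT assay, with a stated time of 48 h (a higher number here means a weaker inhibitor, a lower number a stronger inhibitor), and are half-maximal inhibitory concentrations. Compound 3 sits in the middle of this small set. Compound 3 at 690 nM lies beyond the usual scatter from both of the others, with compound 2 at 2590 nM on the weaker side and compound 1 at 30 nM on the stronger side.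

The next molecule, compound 4 `C=C(c1cc(OC)c(OC)c(OC)c1)c1ccc(OC)c(O)c1NC(=O)CO`, is compound 3 with a single change hydrogen in place of ethyl on an oxygen on a saturated carbon in which hydrogen takes the place of ethyl on an oxygen on a saturated carbon, so that ethoxy becomes hydroxy. Within the data shown here, no measured pair shows this change on its own, so any forecast is rough. Among the measured compounds shown here, the only hint comes from compound 1, which carries the same (hydroxymethyl)carbonyl group and gives 30 nM in this assay, although its core is not identical to that of compound 4. A move toward a stronger inhibitor therefore seems likely, but not all the way to that value. The expected change is a 4.6-fold lower number from compound 3 to compound 4 (0.66 log units; beyond the scatter) and should lie beyond the scatter. The estimate for compound 4 is 150 nM in an expected range from 30 nM to 700 nM.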

Compound 4, half-maximal inhibitory concentration: 20 nM
Estimate against measurement, compound 4: 7.5-fold (0.88 log units) above; measured number outside the range, below it.
By their numbers in this assay, from the lowest: compounds 4 and 1 (each within the scatter of the next); then compound 3; then compound 2.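

In this assay, the only difference between the two compounds is that hydrogen replaces the ethyl group on the oxygen, turning ethoxy into hydroxy, and this gives a 35-fold lower number from compound 3 to compound 4 (1.54 log units; beyond the scatter). Among these compounds, this is the first direct sign that this oxygen is highly sensitive to change, since removing just the two carbons of the ethyl group produces a large step. By contrast, hydroxy in place of hydrogen on the aromatic carbon gives a 1.5-fold lower number from compound 1 to compound 4 (0.18 log units; within the scatter), a step within the scatter, so this aromatic hydroxy has no readable effect when the hydroxymethyl end is present. No measurement shown here explains why the ethyl group makes such a large difference.

On these data alone, it remains open whether a smaller methyl group or a longer propyl chain on the same oxygen would give a number close to that of compound 4 or compound 3, and whether an amine could stand in for the hydroxy. Also unresolved is whether ethyl on this oxygen would have an equally large effect on the core of compound 1, which lacks the aromatic hydroxy.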